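The source may hold more compounds than are shown below. What is called first, only, known or untested is meant among the compounds shown, and "the series" means these compounds.

Among the compounds with values here, in a functional assay for inhibition of sodium/hydrogen exchanger (Oryctolagus cuniculus) (a higher number here means a weaker inhibitor, a lower number a stronger inhibitor), compound 3 `Cc1cc(Nc2ccccc2)c(S(C)(=O)=O)cc1C(=O)N=C(N)N` gives 21 nM, the second highest of the three numbers so far. Compound 2 `CCCSc1cc(C)c(C(=O)N=C(N)N)cc1S(C)(=O)=O` gives 6.8 nM, and a 3.1-fold higher number from compound 2 to compound 3 (0.49 log units; beyond the scatter). Compound 1 `Cc1cc(-c2ccc(Cl)cc2Cl)c(S(C)(=O)=O)cc1C(=O)N=C(N)N` gives 42 nM; a 2.0-fold lower number from compound 1 to compound 3 (0.30 log units; within the scatter), while a 6.2-fold lower number from compound 1 to compound 2 (0.79 log units; beyond the scatter). Compound 4 `Cc1cc(Nc2cccc(Cl)c2)c(S(C)(=O)=O)cc1C(=O)N=C(N)N` differs from compound 3 by chloro in place of hydrogen on an aromatic carbon, placed meta to a large group. Within the data shown here, none of the measured steps alters a substituent on the anilino ring; each swaps the whole group attached to the shared core, so no step bears directly on this change. The expectation is therefore a step within the scatter, a 1.3-fold lower number from compound 3 to compound 4 (0.12 log units; within the scatter). The value for compound 4 is estimated at 16 nM, with a range from 5 nM to 50 nM.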

Compound 4, half-maximal inhibitory concentration: 33 nM
Beside the measured number, compound 4's estimate is 2.1-fold (0.31 log units) below it; the range from low to high includes it.
By their numbers in this assay, from the lowest: compound 2; then compounds 3, 4 and 1 (each within the scatter of the next).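

In this assay, the only change shown on the anilino ring itself, chloro in place of hydrogen, gives a 1.6-fold higher number from compound 3 to compound 4 (0.20 log units; within the scatter), so this place accepts chloro with no step beyond the scatter. The (3-chlorophenyl)amino group still gives way to propylsulfanyl, with a 4.9-fold higher number from compound 2 to compound 4 (0.69 log units; beyond the scatter), and sits level with 2,4-dichlorophenyl, with a 1.3-fold lower number from compound 1 to compound 4 (0.10 log units; within the scatter). Nothing at hand offers a reason for these steps. Open, as far as these compounds go, is whether methoxy, an amine or a carboxylic acid at this place would move the number beyond the scatter. Also open, from the compounds shown here alone, is whether chloro elsewhere on the anilino ring behaves alike.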